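From 4-Fluorobenzyl to 3,4-Dichlorobenzyl

A few compounds are considered here, and "the series" means these few. Any claim that something is new, unique, unknown or untested is made for them only; others in the source may bear on it.

In a functional assay on A-375 cells (Homo sapiens) for antiproliferative activity (a lower number here means a stronger inhibitor, a higher number a weaker inhibitor), compound 1 (`O=C(Nc1ccc(-c2cscn2)cc1)C1CCN(Cc2ccc(F)c(F)c2)C1`) gives 10000 nM and compound 2 (`O=C(Nc1ccc(-c2cscn2)cc1)C1CCCN(Cc2ccc(F)cc2)C1`) gives 2250 nM as the lower of the two numbers, a gap beyond the usual scatter. These two compounds differ in more than one place, so the gap cannot be tied to a single change. Compound 3 (`O=C(Nc1ccc(-c2cscn2)cc1)C1CCCN(Cc2ccc(Cl)c(Cl)c2)C1`), not yet measured, differs from compound 2 by 3,4-dichlorophenyl in place of 4-fluorophenyl on a saturated chain carbon bound to an amine nitrogen in a ring in one place, with 3,4-dichlorophenyl in place of 4-fluorophenyl on a saturated chain carbon bound to an amine nitrogen in a ring. Among the measured compounds shown here, no measured pair shows this change alone, so only a small gain in this assay is expected, with a 1.5-fold lower number from compound 2 to compound 3 (0.18 log units; within the scatter) as the estimated step. The estimate for compound 3 is 1500 nM within a range of 400 nM to 6000 nM as its likely span.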

Compound 3, half-maximal inhibitory concentration: 1730 nM
Compound 3: middle estimate off by 1.2-fold (0.06 log units), on the low side, within the range that was stated.
By their numbers in this assay, from the lowest: compounds 3 and 2 (each within the scatter of the next); then compound 1.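

Among the compounds shown here, compounds 2 and 3 form the first pair that differs in one place only, so this change can be read on its own. In this assay the move to 3,4-dichlorobenzyl gives a 1.3-fold lower number from compound 2 to compound 3 (0.11 log units; within the scatter) and the two compounds cannot be told apart, so at this position 3,4-dichlorophenyl serves as well as 4-fluorophenyl. Nothing measured here explains this result.

Still open, going by these compounds, is whether a different kind of group at this position, such as an amine, a carboxylic acid or a longer chain, would shift the number beyond the scatter.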